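A few compounds are considered here, and "the series" means these few. Any claim that something is new, unique, unknown or untested is made for them only; others in the source may bear on it.

Working notes on a set that shares one core and differs only in the group on a saturated ring carbon. Compound 1 `CC(=O)N1N=C(c2ccc3ccccc3c2)OC1c1ccccc1Br` gives 5.49 ug/mL in a functional assay on MCF7 cells (Homo sapiens) for antiproliferative activity, read by MTT assay, with a stated time of 48 h; on this read-out higher numbers stand for weaker inhibition and lower numbers for stronger inhibition. Compound 2 `CC(=O)N1N=C(c2ccc3ccccc3c2)OC1c1ccc(Br)cc1` gives 5.07 ug/mL in this assay, the step being a 1.1-fold lower number from compound 1 to compound 2 (0.03 log units; within the scatter). Compound 3 `CC(=O)N1N=C(c2ccc3ccccc3c2)OC1c1ccccc1F` gives 3.44 ug/mL in this assay, the lowest of the three numbers shown, though its steps from the other two, a 1.6-fold lower number from compound 1 to compound 3 (0.20 log units; within the scatter) and a 1.5-fold lower number from compound 2 to compound 3 (0.17 log units; within the scatter), both sit within the scatter, so no ordering can be read from them.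

Compound 4 `CC(=O)N1N=C(c2ccc3ccccc3c2)OC1c1ccccn1` is not yet measured in this assay. It differs from compound 3 in one place: pyridin-2-yl in place of 2-fluorophenyl on a saturated ring carbon. The measured steps that bear on this change are the two that exchange the group on the same saturated ring carbon, a 1.1-fold lower number from compound 1 to compound 2 (0.03 log units; within the scatter) and a 1.5-fold lower number from compound 2 to compound 3 (0.17 log units; within the scatter), and both are within the scatter. Within the data shown here, no measured step introduces a pyridin-2-yl or any ring with a hetero atom, so the change itself has no precedent here. The step to compound 4 is therefore expected to be a 1.2-fold higher number from compound 3 to compound 4 (0.07 log units; within the scatter), nothing beyond the scatter. Compound 4 is estimated at 4 ug/mL in this assay, with a range from 2 ug/mL to 8 ug/mL.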

Compound 4, half-maximal inhibitory concentration: 6.02 ug/mL
Beside the measured number, compound 4's estimate is 1.5-fold (0.18 log units) below it, and the stated range covers the measured number.
By their numbers in this assay, from the lowest: compounds 3, 2, 1 and 4 (each within the scatter of the next).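

Pyridin-2-yl puts the only ring here with a hetero atom, and the only hydrogen-bond acceptor, on this saturated ring carbon, and in this assay the exchange gives a 1.8-fold higher number from compound 3 to compound 4 (0.24 log units; within the scatter) and a 1.2-fold higher number from compound 2 to compound 4 (0.07 log units; within the scatter) and a 1.1-fold higher number from compound 1 to compound 4 (0.04 log units; within the scatter) with no step beyond the scatter. A halogen-bearing phenyl group is therefore not needed at this position for a number in the range shared by the set, and the four compounds cannot be ordered. No measurement is available that would account for this result.

Whether any group at this position moves the number beyond the scatter remains open, since all the groups shown are six-membered aromatic rings. An amine, a carboxylic acid or a longer alkyl chain on this carbon would test that directly.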